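Chloro for Methyl on Two Cores, Cytotoxicity Estimated

This account rests on a few compounds, and the source may have more. Where it says the series, first, only, none or still open, it means among the compounds named here.

The measured compounds:
Compound 1, `COc1ccc(N2CCN(CN3C(=O)/C(=N\NC(=S)NO)c4cc(Cl)ccc43)CC2)cc1`: in an ADME assay on MT4 cells (Homo sapiens) for cytotoxicity, read by spectrophotometry, with a stated time of 5 days (on this read-out lower numbers stand for higher toxicity in this test and higher numbers for lower toxicity in this test), compound 1 gives 279000 nM.
Compound 2, `COc1ccc(N2CCN(CN3C(=O)/C(=N\NC(=S)NO)c4cc(C)ccc43)CC2)cc1`: in this assay compound 2 gives 321000 nM.
Compound 3, `CCn1cc(C(=O)O)c(=O)c2cc(F)c(N3CCN(CN4C(=O)/C(=N\NC(=S)NOC)c5cc(C)ccc54)C(C)C3)c(F)c21`: in this assay compound 3 gives 156000 nM.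

Compound 1 and compound 2 share one core and differ in a single place, (chloro in place of methyl on an aromatic carbon). In this assay this gave a 1.2-fold lower number from compound 2 to compound 1 (0.06 log units; within the scatter), so the two values stand together and nothing can be said about one being more or less toxic than the other.

Compound 3 carries a different core. The difference between the two cores is not broken down here, and the gap between compound 3 and compound 2 lies beyond the scatter while that between compound 3 and compound 1 does not.

Compound 4, `CCn1cc(C(=O)O)c(=O)c2cc(F)c(N3CCN(CN4C(=O)/C(=N\NC(=S)NOC)c5cc(Cl)ccc54)C(C)C3)c(F)c21`, has not yet been measured. It differs from compound 3 by chloro in place of methyl on an aromatic carbon, and the words describing the place match those for the change from compound 2 to compound 1, so it is the same change on the second core.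

Because the earlier step was a 1.2-fold lower number from compound 2 to compound 1 (0.06 log units; within the scatter), the step from compound 3 to compound 4 is expected to be about as small, a 1.2-fold lower number from compound 3 to compound 4 (0.06 log units; within the scatter). Compound 4 is therefore estimated at 135000 nM, expected to fall between 65000 nM and 280000 nM.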

Compound 4, half-maximal cytotoxic concentration: 180000 nM
For compound 4 the middle estimate is 1.3-fold (0.12 log units) below the measured one, and the stated range covers the measured number.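

In this assay, chloro in place of methyl on the aromatic carbon of the second core gave a 1.2-fold higher number from compound 3 to compound 4 (0.06 log units; within the scatter), so compound 3 and compound 4 stand together and neither can be called more or less toxic than the other. Set side by side, the steps on the two cores do not differ beyond what repeated measurement allows: the same change on two cores in this assay, a 1.2-fold lower number (0.06 log units; within the scatter) from compound 2 to compound 1 and a 1.2-fold higher number (0.06 log units; within the scatter) from compound 3 to compound 4, 1.3-fold (0.12 log units) apart, within the scatter of two such steps. This shows that, on these two cores, the change left the read-out within the scatter each time, but it does not show that a change with a clear effect would carry from one core to the other, as neither pair contains a step large enough to test this, and two pairs say nothing about any further core.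

The compounds shown carry only methyl or chloro at this aromatic carbon, so it remains open what a fluoro, methoxy or nitrile group there would do to the read-out. Also open, from the compounds shown here alone, is whether the exchange of methyl for chloro would stay as small on a core bearing an amine or a longer chain in place of the carboxylic acid of compound 3.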